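The source may report more compounds than this note shows. Statements on the series, on what has been measured and on what is new or still open speak of the compounds shown alone.

Compound 1 `O=C(Nc1ccc(-c2cscn2)cc1)C1CCCN(Cc2ccc(F)c(F)c2)C1`: 880 nM
Compound 2 `O=C(Nc1ccc(-c2cscn2)cc1)C1CCCN(Cc2cc(F)cc(F)c2)C1`: 1360 nM

In a functional assay on A-375 cells (Homo sapiens) for antiproliferative activity (a higher number here means a weaker inhibitor, a lower number a stronger inhibitor), compound 2 stands at 1360 nM, within the scatter of compound 1. Compound 3 `O=C(Nc1ccc(-c2cscn2)cc1)C1CCCN(Cc2cccc(F)c2F)C1` differs from it as follows: 2,3-difluorophenyl in place of 3,5-difluorophenyl on a saturated chain carbon bound to an amine nitrogen in a ring. It carries 2,3-difluorophenyl in place of 3,5-difluorophenyl on a saturated chain carbon bound to an amine nitrogen in a ring. Among the measured compounds shown here, only one measured step bears on this exchange, a 1.5-fold higher number from compound 1 to compound 2 (0.19 log units; within the scatter), and it also swaps one difluorophenyl for another. In this assay, no shift beyond the scatter is therefore expected, and no direction can be favoured. The estimated step is a 1.2-fold lower number from compound 2 to compound 3 (0.09 log units; within the scatter). For compound 3 the expected value is 1100 nM, with an estimated range of 480 nM to 2500 nM.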

Compound 3, half-maximal inhibitory concentration: 1480 nM
Beside the measured number, compound 3's estimate is 1.3-fold (0.13 log units) below it; measured number inside the range.
By their numbers in this assay, from the lowest: compounds 1, 2 and 3 (each within the scatter of the next).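

With compound 3 a third difluorophenyl group stands on the saturated chain carbon bound to an amine nitrogen in a ring. In this assay both a 1.1-fold higher number from compound 2 to compound 3 (0.04 log units; within the scatter) and a 1.7-fold higher number from compound 1 to compound 3 (0.23 log units; within the scatter) stay within the scatter, so the 3,4-difluorophenyl, 3,5-difluorophenyl and 2,3-difluorophenyl compounds cannot be told apart here. No supporting evidence bears on this result.

From the compounds shown here alone, what stays open is whether an unsubstituted phenyl, a chlorophenyl or a methoxyphenyl at this place would separate from these three. All the compounds shown carry two fluorines on this ring.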